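The source may hold more compounds than are shown below. What is called first, only, known or untested is meant among the compounds shown, and "the series" means these compounds.

Of the compounds shown here, two have so far been tested in an assay on HEK293 cells for inhibition of protein kinase C zeta type (Homo sapiens), read by 33P incorporation, with a stated time of 40 min, tested at 20 uM, in the presence of a further agent that is not named here; on this read-out higher numbers stand for more inhibition at the one concentration tested (going by the name of the read-out) and lower numbers for less inhibition. Compound 1 `COc1ccc(C2=NN(c3cccc(Cl)c3)C(c3cccc(Cl)c3)C2)cc1` gives 25.3% in this assay, while compound 2 `Oc1ccc(C2=NN(c3cccc(Cl)c3)C(c3ccc(Cl)cc3)C2)cc1` gives 86.2%. Compound 2 therefore stands at the top of the two numbers, and its nearest neighbour, compound 1, sits far enough below it for the gap to lie beyond the usual scatter.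

The next compound to consider is compound 3 `COc1ccc(C2=NN(c3cccc(Cl)c3)C(c3ccc(Cl)cc3)C2)cc1`, which has not yet been measured in this assay. Its structure differs from compound 2 in one place: methyl in place of hydrogen on an oxygen on an aromatic ring. Seen one bond further out, this turns a hydroxy into a methoxy, so the 4-hydroxyphenyl becomes a 4-methoxyphenyl.

Among the measured compounds shown here, no measured pair shows this exact change, so its effect must be estimated rather than read off. A drop is expected for compound 3 relative to compound 2, because compound 1, which also carries a methoxy, gives only 25.3%. The expected step from compound 2 to compound 3 is a number 46.2 percentage points lower from compound 2 to compound 3 (beyond the scatter), beyond the scatter. Compound 3 is accordingly estimated at 40%, within a range of 15% to 70%.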

Compound 3, a percentage reported as inhibition, at one concentration (the size of the read-out at that concentration, not a potency): 30.8%
Compound 3: the middle estimate sits 9.2 percentage points above what was measured; the measured number falls inside the stated range.
By their numbers in this assay, from the lowest: compounds 1 and 3 (each within the scatter of the next); then compound 2.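

In this assay, the hydroxy-to-methoxy change on the 4-hydroxyphenyl can now be read as a single change, a number 55.4 percentage points lower from compound 2 to compound 3 (beyond the scatter), so one methyl placed on that oxygen is enough to remove most of the inhibition seen with compound 2. The second pair, with 4-chlorophenyl in place of 3-chlorophenyl on a saturated ring carbon, reads a number 5.5 percentage points higher from compound 1 to compound 3 (within the scatter), so the two chlorophenyl groups cannot be told apart in this assay when the methoxy is present. Nothing measured here explains why the methyl has so large an effect.

With only hydroxy and methoxy shown at this place, it remains open how an amine, a carboxylic acid or a longer chain such as ethoxy would read in place of the hydroxy. It is also open whether the two chlorophenyl groups would still read alike with the hydroxy present, as the only hydroxy compound shown carries the 4-chlorophenyl.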